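A few compounds are considered here, and "the series" means these few. Any claim that something is new, unique, unknown or untested is made for them only; others in the source may bear on it.

Working notes on the series

Three analogues have been measured in a functional assay on A549 cells (Homo sapiens) for cytotoxicity, read by WST assay, with a stated time of 24 h; on this read-out higher numbers stand for weaker inhibition and lower numbers for stronger inhibition. Compound 1 `COc1ccc2c(/C=C(\C#N)C(=O)c3c[nH]c4cc(OC)ccc34)c[nH]c2c1` gives 1900 nM. Compound 3 `COc1ccc2c(C(=O)/C(C#N)=C/c3c[nH]c4cc(F)ccc34)c[nH]c2c1` gives 2400 nM. Compound 2 `COc1ccc2[nH]cc(/C=C(\C#N)C(=O)c3c[nH]c4cc(F)ccc34)c2c1` gives 18000 nM; it stands at the high end of the three values, and its nearest neighbour is compound 3. Compound 2 and compound 3 are built from the same atoms joined differently; the difference between the two cores is not broken down here.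

Going by the values given here, the one single-point change measured so far is methoxy in place of fluoro on an aromatic carbon, and it gives a 1.3-fold lower number from compound 3 to compound 1 (0.10 log units; within the scatter).

Compound 4 `COc1ccc2c(C(=O)/C(C#N)=C/c3c[nH]c4ccc(OC)cc34)c[nH]c2c1` has not yet been measured in this assay. It arises from compound 2 by methoxy in place of fluoro on an aromatic carbon, and the place of this change reads the same as for the pair of compound 3 and compound 1, so it is the same change on the other core.

For compound 4 the step from compound 2 is expected to be a 1.3-fold lower number from compound 2 to compound 4 (0.11 log units; within the scatter), a small one, because the same change on compound 3 gave only a 1.3-fold lower number from compound 3 to compound 1 (0.10 log units; within the scatter). On these data alone, whether a change that barely moved one core moves the other remains open. Compound 4 is therefore expected to give about 14000 nM in this assay, with a likely range of 6000 nM to 30000 nM.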

Compound 4, half-maximal inhibitory concentration: 3700 nM
The estimate for compound 4 lay 3.8-fold (0.58 log units) above the measured number; measured number below the stated range.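

In this assay, methoxy in place of fluoro on an aromatic carbon gives a 4.9-fold lower number from compound 2 to compound 4 (0.69 log units; beyond the scatter), so in this series the size of the step does not carry over unchanged from one core to the other: the same change on two cores in this assay, a 1.3-fold lower number (0.10 log units; within the scatter) from compound 3 to compound 1 and a 4.9-fold lower number (0.69 log units; beyond the scatter) from compound 2 to compound 4, 3.9-fold (0.59 log units) apart, beyond the scatter of two such steps.

The step is beyond the scatter on the core of compound 2 but within it on the core of compound 3, so a small step on one core gave no guide to the size of the step on the other. This rests on a single change in two pairs, and it shows neither why the cores differ nor whether other changes would behave in the same way.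

The compounds shown leave open whether an amine, a hydroxy group or a longer alkoxy chain in place of fluoro would also give steps that differ between the two cores. They also leave open how either core would respond if a carboxylic acid took the place of the nitrile.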